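A few compounds are considered here, and "the series" means these few. Any claim that something is new, unique, unknown or untested is made for them only; others in the source may bear on it.

Compound 3, with the structure `C/C(=N\NC(=O)COc1cccc2ccccc12)c1ccccc1`, is the plain-phenyl member of a small set of hydrazones that share one core. In an ADME assay on MT4 cells (Homo sapiens) for cytotoxicity, read by MTT assay, with a stated time of 4 days (on this read-out higher numbers stand for lower toxicity in this test and lower numbers for higher toxicity in this test), compound 3 gives 105 ug/mL. Within the data shown here, compound 1 `C/C(=N\NC(=O)COc1cccc2ccccc12)c1ccc(O)cc1O` gives 59.9 ug/mL and compound 2 `C/C(=N\NC(=O)COc1cccc2ccccc12)c1ccc([N+](=O)[O-])cc1` gives 89.3 ug/mL, so every step among the three, a 1.5-fold higher number from compound 1 to compound 2 (0.17 log units; within the scatter), a 1.8-fold higher number from compound 1 to compound 3 (0.24 log units; within the scatter) and a 1.2-fold higher number from compound 2 to compound 3 (0.07 log units; within the scatter), lies within the scatter of repeated measurements, and no compound can be set apart from the others on these numbers.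

Compound 4 `C/C(=N\NC(=O)COc1cccc2ccccc12)c1ccccc1Br` is reached from compound 3 by bromo in place of hydrogen on an aromatic carbon. Among the measured compounds shown here, the steps that bear on this are those in which the group on the same aromatic ring was changed: the swap of nitro for hydrogen, and the larger swaps of the whole ring. All of them stayed within the scatter in this assay, so the expected step of a 1.1-fold lower number from compound 3 to compound 4 (0.02 log units; within the scatter) is none beyond the scatter. Compound 4 is therefore estimated to give 100 ug/mL in this assay, with a range from 50 ug/mL to 200 ug/mL.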

Compound 4, half-maximal cytotoxic concentration: 79.8 ug/mL
Estimate against measurement, compound 4: 1.3-fold (0.10 log units) above; low and high end bracket the measured number.
By their numbers in this assay, from the lowest: compounds 1, 4, 2 and 3 (each within the scatter of the next).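

In this assay, bromo in place of hydrogen, ortho to a large group, adds one heavy atom and gives a 1.3-fold lower number from compound 3 to compound 4 (0.12 log units; within the scatter) and so does not set compound 4 apart from compound 3 at this position. The swaps of the whole ring read the same way, with a 1.1-fold lower number from compound 2 to compound 4 (0.05 log units; within the scatter) and with a 1.3-fold higher number from compound 1 to compound 4 (0.12 log units; within the scatter) as the two steps that place the 2-bromophenyl ring alongside the 4-nitrophenyl and 2,4-dihydroxyphenyl rings, so all four compounds remain indistinguishable on this read-out. No measurement offered here accounts for the small differences that remain.

On these data alone, whether an amine or a carboxylic acid at this same place would give a step beyond the scatter stays open. So does whether a change in the shared core, such as a longer chain, would separate these compounds.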